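The compounds below may be only part of what the source reports. "The series", "measured", "known", "first", "only" and "open" are said of these compounds alone.

Going by the values given here, in an ADME assay on HEK293 cells (Homo sapiens) for cytotoxicity, read by resazurin assay, with a stated time of 48 h (on this read-out lower numbers stand for higher toxicity in this test and higher numbers for lower toxicity in this test), only two compounds have been read so far. Among the compounds with values here, compound 1 `COc1ccc(S(=O)(=O)Nc2ccc3oc(-c4ccc(NC(=O)c5cccc(C)c5[N+](=O)[O-])cc4)nc3c2)cc1` gives 12000 nM, the only actual number in the set. Compound 2 `COc1c(Br)cccc1C(=O)Nc1ccc(Sc2nc3ccccc3s2)cc1` reads > 100000 nM, which is a limit of the assay and not a number.

Compound 3 `COc1ccc(S(=O)(=O)Nc2ccc3oc(-c4ccc(NS(=O)(=O)c5cc(F)ccc5OC)cc4)nc3c2)cc1` has not yet been measured. It keeps the rest of compound 1 and differs in one place, on a nitrogen on an aromatic ring: a group of 12 heavy atoms (7 carbon, 3 oxygen, 1 fluorine, 1 sulfur; one six-membered aromatic ring of carbon only) in place of a group of 12 heavy atoms (8 carbon, 1 nitrogen, 3 oxygen; one six-membered aromatic ring of carbon only), on a nitrogen on an aromatic ring. The (3-methyl-2-nitrophenyl)carbonyl group leaves, and the group that enters also holds one six-membered aromatic ring of carbon only.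

Within the data shown here, no measured pair shows a change of this kind, so the data give no step to carry over. No change beyond the scatter is therefore expected in this assay, and neither direction is favoured, though the uncertainty is wide. The expectation is anchored on compound 1 at 12000 nM. The expected change is small, a 1.2-fold higher number from compound 1 to compound 3 (0.07 log units; within the scatter). For compound 3 the estimated value is 14000 nM, with an expected range from 4000 nM to 50000 nM.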

Compound 3, half-maximal cytotoxic concentration: 24000 nM
For compound 3 the middle estimate is 1.7-fold (0.23 log units) below the measured one; low and high end bracket the measured number.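

In this assay, the exchange of the (3-methyl-2-nitrophenyl)carbonyl group for a group holding sulfur and fluorine, on a nitrogen on an aromatic ring, gives a 2.0-fold higher number from compound 1 to compound 3 (0.30 log units; within the scatter). Going by these compounds alone, this is the first step that can be read at this place, and it shows that compound 1 and compound 3 cannot be told apart in this test, even though the leaving group holds a nitrogen and the entering group a sulfur and a fluorine, with the same count of heavy atoms and one six-membered aromatic ring of carbon only on each side. Compound 2 remains a limit of the assay and not a number, and no step links it to the other two compounds: the limit of > 100000 nM in this assay, at which 1 of the 3 values shown sits.

Within the data shown here, the single step changes several atoms at once, so it leaves open what the nitro group, the methyl group, the fluorine or the methoxy group each contribute on their own. It also leaves open how the read-out would respond at this nitrogen to a group without an aromatic ring, such as an acetyl group, or to one carrying an amine or a carboxylic acid.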